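The source may report more compounds than this note shows. Statements on the series, on what has been measured and on what is new or still open speak of the compounds shown alone.

Compound 2 `CC1=C(C(=O)SC(C)C)C(c2ccoc2)NC(=O)N1` shares its core with compound 1 `CCCC(=O)C1=C(C)NC(=O)NC1c1ccoc1`; the two differ only in the group carried on a carbonyl carbon. In an assay on membranes from HeLa cells for displacement of a labelled ligand from adenosine receptor A3 (Homo sapiens), read by scintillation counting, with a stated time of 180 min, tested at 1 uM (a higher number here means more inhibition at the concentration tested (going by the name of the read-out), a lower number less inhibition), compound 1 gives 2%, and in this assay compound 2 gives 3%. Among the measured compounds shown here, that leaves compound 2 standing highest of the two numbers known so far, though only by a number 1 percentage points higher from compound 1 to compound 2 (within the scatter), a gap that says nothing about which of the two is really the stronger.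

Compound 3 `CC1=C(C(=O)OCC2CC2)C(c2ccoc2)NC(=O)N1` is the next compound in line and has not yet been measured. It differs from compound 2 in one place: cyclopropylmethoxy in place of isopropylsulfanyl on a carbonyl carbon. For the measured compounds named here, the one step already measured at this same carbonyl carbon, a number 1 percentage points higher from compound 1 to compound 2 (within the scatter), shows that trading one small group for another there left the read-out essentially unchanged. Since compound 3 again swaps a small group at that carbon, and since both measured compounds sit near the bottom of the scale, the expected step of no change at the digits printed from compound 2 to compound 3 (within the scatter) is one of no size beyond the scatter. Compound 3 is therefore estimated to give 3% in this assay, most likely between -7% and 13%.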

Compound 3, a percentage reported as inhibition, at one concentration (the size of the read-out at that concentration, not a potency): 3%
Beside the measured number, compound 3's estimate shows no gap at the digits printed; measured number inside the range.
By their numbers in this assay, from the lowest: compounds 1, 2 and 3 (each within the scatter of the next).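

The swap at this carbonyl carbon is a larger change than the first one, yet in this assay it gives no change at the digits printed from compound 2 to compound 3 (within the scatter) and no separation: the sulfur of isopropylsulfanyl gives way to the oxygen of cyclopropylmethoxy, and a three-membered ring of carbon enters. Set against the propyl group of the first compound, the same new group gives a number 1 percentage points higher from compound 1 to compound 3 (within the scatter) and so again stays within the scatter, which means three groups of different make-up at this one place now give readings that cannot be told apart, all of them close to the bottom of the scale. No separate measurement bears on this result, so the flat readings stand here as an observation without an explanation.

The compounds shown leave open whether any group at this carbonyl carbon can lift the reading clear of the scatter, for instance an amine, a carboxylic acid or a much longer chain. Among the compounds shown here, they also leave open whether a change elsewhere on the shared core would move the number at all, since every step so far falls at this single place.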